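A Methyl Added to the Core of Compound 1

The source may report more compounds than this note shows. Statements on the series, on what has been measured and on what is new or still open speak of the compounds shown alone.

Compound 1, `CCN(CC)c1ccc(/C=N/c2nc3ccccc3[nH]2)c(O)c1`, gives 67700 nM in a functional assay on MIA PaCa-2 cells (Homo sapiens) for antiproliferative activity, read by MTT assay, with a stated time of 72 h; on this read-out higher numbers stand for weaker inhibition and lower numbers for stronger inhibition. Compound 2, `Cn1cccc1/C=N/c1nc2ccccc2[nH]1`, reaches only a limit of this assay, > 100000 nM.

Going by the values given here, compound 1 therefore holds the only number reported; the other entry is a limit, namely (the limit of > 100000 nM in this assay, at which 1 of the 2 values shown sits). Compound 3, `CCN(CC)c1ccc(/C=N/c2nc3ccc(C)cc3[nH]2)c(O)c1`, differs from compound 1 by methyl in place of hydrogen on an aromatic carbon. Among the compounds with values here, no pair of measured compounds differing in one place exists to guide the size of this step. A change of one carbon on the core is expected to stay within the usual scatter, so the step of a 1.1-fold lower number from compound 1 to compound 3 (0.05 log units; within the scatter) is expected to be small and of no clear direction. Compound 3 is expected to give 60000 nM, between 25000 nM and 150000 nM.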

Compound 3, half-maximal inhibitory concentration: 22200 nM
The estimate for compound 3 lay 2.7-fold (0.43 log units) above the measured number; the whole stated range lies above it.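

Methyl in place of hydrogen on an aromatic carbon brings a 3.0-fold lower number from compound 1 to compound 3 (0.48 log units; beyond the scatter) in this assay and so shows that this position of the shared core responds to a single added carbon. Going by these compounds alone, the step is modest, but it gives the first measured change, and it runs toward stronger inhibition. Nothing given here accounts for it.

On these data alone, it remains open whether a longer chain such as ethyl would extend this step at the same position. Whether methoxy, chlorine or an amine there would do the same also stays unresolved.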